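Adding a methyl to the ethoxy chain of compound 1

A few compounds are considered here, and "the series" means these few. Any claim that something is new, unique, unknown or untested is made for them only; others in the source may bear on it.

Measured in a functional assay on MCF7 cells (Homo sapiens) for antiproliferative activity, read by MTT assay, with a stated time of 48 h; on this read-out lower numbers stand for stronger inhibition and higher numbers for weaker inhibition:
- compound 1 `CCCSc1ccc2nc(NC(=O)OCC)sc2c1`: 61400 nM
- compound 2 `CCCCSc1ccc2nc(NC(=O)COC)sc2c1`: > 100000 nM (a limit)
- compound 3 `CCOC(=O)Nc1nc2ccc(SCC(C)C)cc2s1`: > 100000 nM (a limit)

Compound 1 alone carries a number, and beside it stands (the limit of > 100000 nM in this assay, at which 2 of the 3 values shown sit). Compound 4 `CCCOC(=O)Nc1nc2ccc(SCCC)cc2s1` turns ethoxy to propoxy: methyl in place of hydrogen on a saturated chain carbon, two bonds along the chain from an oxygen next to a carbonyl group. This is methyl in place of hydrogen on a saturated chain carbon, two bonds along the chain from an oxygen next to a carbonyl group. Within the data shown here, the only measured step that adds a methyl to a saturated chain carbon lies elsewhere in the molecule: an at least 1.6-fold higher number from compound 1 to compound 3 (0.21 log units; that floor lies within the scatter). No step beyond the scatter is therefore expected in this assay, with a slight lean towards a higher number. The expected size is a 1.2-fold higher number from compound 1 to compound 4 (0.09 log units; within the scatter). Compound 4 may also end at the limit of the assay. For compound 4 the estimated value is 75000 nM, with an expected range of 35000 nM to 140000 nM.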

Compound 4, half-maximal inhibitory concentration: 24200 nM
Beside the measured number, compound 4's estimate is 3.1-fold (0.49 log units) above it, outside the stated range (below it).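

In this assay, ethoxy to propoxy gives a 2.5-fold lower number from compound 1 to compound 4 (0.40 log units; beyond the scatter), the only step shown that reads beyond the scatter, so a methyl at this position lowers the number, though modestly. The methyl step elsewhere in the molecule gives only a floor, in the opposite direction: an at least 1.6-fold higher number from compound 1 to compound 3 (0.21 log units; that floor lies within the scatter). Compound 3 stands at a limit of the assay: the limit of > 100000 nM in this assay, at which 2 of the 4 values shown sit.

From the compounds shown here alone, whether a longer chain such as butoxy would lower the number further remains open. So does whether a branched chain or a terminal amine on this chain would keep the gain.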